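A Two-Carbon Ether Tail on the Methylamino Group

The source may hold more compounds than are shown below. What is called first, only, known or untested is meant among the compounds shown, and "the series" means these compounds.

Compound 1 `Nc1nc(Cl)c(-c2nc3ccccc3s2)c(N[C@@H]2C[C@H](CO)[C@@H](O)[C@H]2O)n1`: 14000 nM
Compound 2 `COc1ccc2nc(-c3c(Cl)nc(N)nc3N[C@@H]3C[C@H](CO)[C@@H](O)[C@H]3O)sc2c1`: > 25000 nM
Compound 3 `CNc1nc(C)c(-c2nc3ccccc3s2)c(N[C@@H]2C[C@H](CO)[C@@H](O)[C@H]2O)n1`: > 25000 nM

In an ADME assay on cells (Homo sapiens) for cytotoxicity, read by polymerase chain reaction, with a stated time of 3 days (on this read-out higher numbers stand for lower toxicity in this test and lower numbers for higher toxicity in this test), compound 1 gives 14000 nM. Compound 2 reaches > 25000 nM, which is a limit of the test rather than a number. Compound 3 likewise gives only a limit, > 25000 nM. Compound 3 therefore stands at the ceiling of what this assay reports, one of the two compounds at the limit of > 25000 nM in this assay, at which 2 of the 3 values shown sit.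

Compound 4 `CCOCCNc1nc(C)c(-c2nc3ccccc3s2)c(N[C@@H]2C[C@H](CO)[C@@H](O)[C@H]2O)n1` differs from compound 3 by ethoxymethyl in place of hydrogen on a saturated chain carbon bound to a nitrogen on an aromatic ring. Among the measured compounds shown here, the single measured step, an at least 1.7-fold higher number from compound 1 to compound 2 (0.25 log units; that floor lies within the scatter), concerns a methoxy on an aromatic carbon, a different place in the molecule, and stays within the scatter; it gives no direct guide to a change on a saturated chain carbon bound to a nitrogen on an aromatic ring. With compound 3 already at the limit, no step beyond the scatter is expected, and the estimated step of an at least 1.1-fold lower number from compound 3 to compound 4 (0.05 log units; that floor lies within the scatter) is essentially flat. Compound 4 is therefore expected to give about 22000 nM in this assay, between 8000 nM and 60000 nM, most likely again reported only as a limit.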

Compound 4, half-maximal cytotoxic concentration: 18000 nM
For compound 4 the middle estimate is 1.2-fold (0.09 log units) above the measured one, within the range that was stated.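

In this assay, ethoxymethyl in place of hydrogen on a saturated chain carbon bound to a nitrogen on an aromatic ring gives a step that stays inside the usual scatter: an at least 1.3-fold lower number from compound 3 to compound 4 (0.14 log units; that floor lies within the scatter). Compound 4 gives 18000 nM, a true number rather than a limit, so this series now has a readable value with the methylamino position carrying a longer group, and the added ether tail brings no clear gain in toxicity. The full size of the step remains unknown, because compound 3 sits at a limit and not at a number: the limit of > 25000 nM in this assay, at which 2 of the 4 values shown sit.

On these data alone, whether an amine, a carboxylic acid or a longer chain at this position would give a similar reading stays open. So does whether the same tail would behave alike on a core carrying the methoxy of compound 2.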